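A second fluorine on a weak compound

The source may hold more compounds than are shown below. What is called first, only, known or untested is meant among the compounds shown, and "the series" means these compounds.

Compound 1 `Cn1nc(-c2ccccc2)c2c1OC(N)=C(C#N)C2c1ccc(F)cc1` is the starting point. In a functional assay on NCI-H2122 cells (Homo sapiens) for inhibition, read by microscopy, with a stated time of 10 days (on this read-out lower numbers stand for stronger inhibition and higher numbers for weaker inhibition), compound 1 gives > 10000 nM and this is a limit of the assay, not a number. Compound 2 `N#CC1=C(N)Oc2c(c(-c3ccccc3)nn2-c2ccccc2)C1c1ccc(F)cc1` carries phenyl in place of methyl on an aromatic nitrogen. In this assay compound 2 gives 4100 nM as a true number. Among the measured compounds shown here, that change is an at least 2.4-fold lower number from compound 1 to compound 2 (0.38 log units; beyond the scatter) and it is the only measured step available. It sits at a different place from the change considered here, so its size cannot simply be carried over.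

For the measured compounds named here, compound 3 `Cn1nc(-c2ccccc2)c2c1OC(N)=C(C#N)C2c1cc(F)cc(F)c1` keeps the core of compound 1 and alters only one group. The change is 3,5-difluorophenyl in place of 4-fluorophenyl on a saturated ring carbon and nothing else differs. Going by the values given here, with no measured step at this place, no step beyond the scatter is expected in this assay and compound 3 may well return only a limit too. The estimate amounts to a number no higher from compound 1 to compound 3 (the limit leaves the size open) as the expected step. Compound 3 is expected near 10000 nM with an estimated range from 3500 nM to 30000 nM for a measured number.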

Compound 3, half-maximal inhibitory concentration: 6600 nM
Beside the measured number, compound 3's estimate is 1.5-fold (0.18 log units) above it; the measured number falls inside the stated range.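

Among the compounds shown here, at the saturated ring carbon, the core of compound 1 now yields a true number: in this assay compound 3 gives 6600 nM, so this position can be read on a measured scale for the first time. Replacing 4-fluorophenyl with 3,5-difluorophenyl amounts to an at least 1.5-fold lower number from compound 1 to compound 3 (0.18 log units; that floor lies within the scatter), which shows only a smallest possible step, and that smallest step cannot be told apart from ordinary repeat variation. The real size of the step stays open because the starting point is a limit of the assay and not a number: the limit of > 10000 nM in this assay, at which 1 of the 3 values shown sits.

So the result places a measured value on the methyl-bearing compounds, but it does not establish that the second fluorine improves inhibition by any definite amount. Among the compounds shown, this carbon carries only fluorinated phenyl rings, so how a plain phenyl, a methoxyphenyl or a pyridine ring would read there remains open, as does whether the same swap would change the number when phenyl sits on the aromatic nitrogen, as in compound 2.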